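Replacing 3,5-dimethoxyphenyl with 3-bromophenyl: expectations for compound 3

The source may report more compounds than this note shows. Statements on the series, on what has been measured and on what is new or still open speak of the compounds shown alone.

In an ADME assay on Raji cells (Homo sapiens) for cytotoxicity, read by CellTiter-Glo and resazurin assay, with a stated time of 72 h (a higher number here means that more compound is needed for the effect, a lower number that less compound is needed), compound 1 `CCOC(=O)CCCCCOc1cccc(CN(C(=O)c2ccc(-c3cccc(Oc4ccccc4)c3)cc2)C(C)C)c1` gives > 19600 nM, which is a limit and not a number. Compound 2 `CCOC(=O)CCCCCOc1cccc(CN(C(=O)c2ccc(-c3cc(OC)cc(OC)c3)cc2)C(C)C)c1` gives > 26000 nM, which is likewise a limit. Compound 2 therefore has no exact value in this assay, and the only other result available is also a limit.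

Compound 3 `CCOC(=O)CCCCCOc1cccc(CN(C(=O)c2ccc(-c3cccc(Br)c3)cc2)C(C)C)c1` carries 3-bromophenyl in place of 3,5-dimethoxyphenyl on an aromatic carbon, para to a large group: 3-bromophenyl in place of 3,5-dimethoxyphenyl on an aromatic carbon. Among the compounds with values here, no measured step is available as a guide, and no change beyond the scatter is expected in this assay. The expected change is an at least 1.0-fold lower number from compound 2 to compound 3 (0.01 log units; that floor lies within the scatter). This expectation rests on the limit of compound 2 at > 26000 nM. A limit may be all that is reported again. For compound 3 the estimate is 25000 nM, with an expected range of 10000 nM to 45000 nM.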

Compound 3, half-maximal effective concentration: > 26000 nM
Compound 3 was reported as a limit; the forecaster's own chance of this, stated with the estimate: 75%; at least 1.0-fold (0.01 log units) between middle value and limit.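

Compound 1, compound 2 and compound 3 are all reported as limits in this assay; no step can be read from compound 1 or compound 2 to compound 3. The compounds shown leave open the concentration at which any of the three reaches the half-maximal effect.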